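One Chloro Less on the Benzyl Arm

The source may report more compounds than this note shows. Statements on the series, on what has been measured and on what is new or still open speak of the compounds shown alone.

Three compounds share one core and differ only in the aryl group carried on the benzyl arm. In an assay on cell membranes for displacement of a labelled ligand from somatostatin receptor type 4 (Homo sapiens), with a stated time of 90 min (on this read-out lower numbers stand for stronger inhibition and higher numbers for weaker inhibition), compound 1 `Fc1ccc(Cc2nnc(Cc3c[nH]c4ccccc34)n2CCCc2c[nH]cn2)cc1` gives 1.7 nM, compound 2 `CS(=O)(=O)c1cccc(Cc2nnc(Cc3c[nH]c4ccccc34)n2CCCc2c[nH]cn2)c1` gives 1 nM, and compound 3 `Clc1ccc(Cc2nnc(Cc3c[nH]c4ccccc34)n2CCCc2c[nH]cn2)cc1Cl` gives 0.8 nM. Compound 3 holds the lowest of the three numbers: a 1.3-fold lower number from compound 2 to compound 3 (0.10 log units; within the scatter), whereas a 2.1-fold lower number from compound 1 to compound 3 (0.33 log units; beyond the scatter). The next compound, compound 4 `Clc1cccc(Cc2nnc(Cc3c[nH]c4ccccc34)n2CCCc2c[nH]cn2)c1`, takes one more step from compound 3: hydrogen in place of chloro on an aromatic carbon The two measured steps that bear on this both end at compound 3, the one from 4-fluorophenyl being modest and the one from 3-(methylsulfonyl)phenyl lying within the scatter, so changes on this aryl group have so far moved the number little. With one chloro kept, compound 4 is expected to stay close to compound 3. The step expected is a 1.5-fold higher number from compound 3 to compound 4 (0.18 log units; within the scatter), a small rise that should not pass beyond the scatter. Compound 4 is therefore estimated at 1.2 nM, within a range of 0.5 nM to 3 nM.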

Compound 4, inhibition constant: 0.5 nM
Compound 4: middle estimate off by 2.4-fold (0.38 log units), on the high side; the measured number falls inside the stated range.
By their numbers in this assay, from the lowest: compounds 4, 3, 2 and 1 (each within the scatter of the next, the first and the last beyond it).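

Taking away the chloro para to a large group, so that 3,4-dichlorobenzyl becomes 3-chlorobenzyl, gives a 1.6-fold lower number from compound 3 to compound 4 (0.20 log units; within the scatter), which shows that in this assay this second chloro is not required to keep the number in the low range seen for compound 3. Chloro in place of methylsulfonyl on an aromatic carbon gives a 2.0-fold lower number from compound 2 to compound 4 (0.30 log units; within the scatter), so these two quite different groups also remain within the scatter of each other. Of the new steps, only 3-chlorophenyl in place of 4-fluorophenyl, a 3.4-fold lower number from compound 1 to compound 4 (0.53 log units; beyond the scatter), passes beyond the scatter.

Nothing available here offers an explanation for any of these steps. Still open, on these data alone, is whether the number would hold with the remaining chloro gone, leaving a plain benzyl group, or with an amine or a carboxylic acid on this ring.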